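A few compounds are considered here, and "the series" means these few. Any claim that something is new, unique, unknown or untested is made for them only; others in the source may bear on it.

Measured so far in a functional assay on HT-29 cells (Homo sapiens) for antiproliferative activity, read by MTT assay, with a stated time of 24 h; on this read-out lower numbers stand for stronger inhibition and higher numbers for weaker inhibition:

Compound 1 `COc1ccc(C(=O)/C=C/c2cccc([N+](=O)[O-])c2)c2c1C=CC(C)(C)O2` gives 4260 nM
Compound 2 `COc1ccc(C(=O)/C=C/c2cccc(C(F)(F)F)c2)c2c1C=CC(C)(C)O2` gives 9050 nM

Compound 1 holds the lower of these two numbers, which makes it the stronger inhibitor of the pair. Compound 3 `COc1ccc(C(=O)/C=C/c2cccs2)c2c1C=CC(C)(C)O2` keeps the core of compound 1 but changes the ring at the end of the chain: thiophen-2-yl in place of 3-nitrophenyl on a double-bonded chain carbon bound to a double-bonded chain carbon. Going by the values given here, the one measured step, a 2.1-fold higher number from compound 1 to compound 2 (0.33 log units; beyond the scatter), swapped nitro for trifluoromethyl and was modest. Among the compounds with values here, compound 3 also lacks the nitro group, but that step left the six-membered aromatic ring in place, and no measured compound carries thiophen-2-yl. It is therefore only a loose guide. A small rise in this assay is expected, possibly none beyond the scatter. For compound 3 the estimated value is 6500 nM, with an expected range of 2500 nM to 17000 nM. That estimate means a 1.5-fold higher number from compound 1 to compound 3 (0.18 log units; within the scatter).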

Compound 3, half-maximal inhibitory concentration: > 10000 nM
Compound 3 was reported as a limit; the forecaster's own chance of this, stated with the estimate: 5%; middle value at least 1.5-fold (0.18 log units) from the limit.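

In this assay, replacing 3-nitrophenyl with thiophen-2-yl on a double-bonded chain carbon bound to a double-bonded chain carbon gives an at least 2.3-fold higher number from compound 1 to compound 3 (0.37 log units; beyond the scatter). So far only a group on the six-membered aromatic ring had been exchanged; this change replaces the whole ring and shows that inhibition at this position also responds to the ring itself, with compound 1 remaining the stronger inhibitor of the pair. The result for compound 3 is a limit and not a number, so the true size of this step stays unknown: the limit of > 10000 nM in this assay, at which 1 of the 3 values shown sits.

This change removes the nitro group and the six-membered ring together, and the compounds shown do not separate the two. Also open, from the compounds shown here alone, is how a plain phenyl ring or a furan-2-yl ring would behave at this position.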